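Swapping the fluoropyridine on the shared core

The source may hold more compounds than are shown below. What is called first, only, known or untested is meant among the compounds shown, and "the series" means these compounds.

- compound 1 `CN1CCN(c2cc(C(F)(F)F)ccc2[C@H]2CCOc3cc(S(=O)(=O)Nc4nccs4)ccc32)CC1`: 176000 nM
- compound 2 `Cn1nccc1-c1cc(C(F)(F)F)ccc1[C@H]1CCOc2cc(S(=O)(=O)Nc3nccs3)ccc21`: 83000 nM
- compound 3 `O=S(=O)(Nc1nccs1)c1ccc2c(c1)OCC[C@@H]2c1ccc(C(F)(F)F)cc1-c1ccc(F)cn1`: 7000 nM

In a physicochemical assay for solubility (a lower number here means a less soluble compound, a higher number a more soluble compound), compound 3 stands lowest of the three at 7000 nM. Compound 4 `O=S(=O)(Nc1nccs1)c1ccc2c(c1)OCC[C@@H]2c1ccc(C(F)(F)F)cc1-c1ccc(F)nc1` has 6-fluoropyridin-3-yl in place of 5-fluoropyridin-2-yl, ortho to a large group: 6-fluoropyridin-3-yl in place of 5-fluoropyridin-2-yl on an aromatic carbon. The measured steps at this place are a 25-fold lower number from compound 1 to compound 3 (1.40 log units; beyond the scatter) and a 12-fold lower number from compound 2 to compound 3 (1.07 log units; beyond the scatter), both large, and a 2.1-fold lower number from compound 1 to compound 2 (0.33 log units; beyond the scatter), modest. Each exchanges unlike groups, and none tests one pyridinyl isomer against another. Compound 4 holds the same atoms as compound 3, so no step beyond the scatter is expected, in either direction. The expected change is a 1.1-fold higher number from compound 3 to compound 4 (0.06 log units; within the scatter). Compound 4 is estimated at 8000 nM, with an expected range of 2500 nM to 25000 nM.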

Compound 4, solubility: 21000 nM
Compound 4: the middle estimate sits 2.6-fold (0.42 log units) below what was measured; the measured number falls inside the stated range.
By their numbers in this assay, from the lowest: compound 3; then compound 4; then compound 2; then compound 1.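

In this assay this position separates two pyridinyl isomers with the same atoms, since a 3.0-fold higher number from compound 3 to compound 4 (0.48 log units; beyond the scatter) lies beyond the scatter. The 6-fluoropyridin-3-yl group still leaves a gap to the other two groups, with a 4.0-fold lower number from compound 2 to compound 4 (0.60 log units; beyond the scatter) and an 8.4-fold lower number from compound 1 to compound 4 (0.92 log units; beyond the scatter) remaining. No supporting data bear on why the two isomers differ.

Open, as far as these compounds go, is whether the gap between isomers survives when an amine or a methoxy group replaces the fluorine on the pyridine. Also open, from the compounds shown here alone, is whether a saturated amine other than 4-methylpiperazin-1-yl matches the number of compound 1 176000 nM.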